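Chloro to methoxy on the pendant phenyl of compound 1

The compounds below may be only part of what the source reports. "The series", "measured", "known", "first", "only" and "open" are said of these compounds alone.

Compound 1 `CN1CCN(CC(=O)NC2(c3ccc(Cl)cc3)C(=O)Nc3cc(Cl)c(Cl)cc32)CC1` is the starting point. In an in vitro functional assay on CHO-CREluc cells for antagonist activity at growth hormone secretagogue receptor type 1 (Homo sapiens), read by a luciferase reporter, with a stated time of 4 h (a lower number here means a stronger inhibitor, a higher number a weaker inhibitor), compound 1 gives > 10000 nM, which is a limit of the assay and not a number, so compound 1 stands at the weak end of what has been measured in this series. Compound 2 `Cc1cc2c(cc1Cl)C(NC(=O)CN1CCN(C)CC1)(c1ccc(Cl)cc1)C(=O)N2` differs from compound 1 by a methyl in place of chloro on an aromatic carbon of the shared core; in this assay compound 2 gives 251 nM. That single measured step, an at least 39-fold lower number from compound 1 to compound 2 (1.60 log units; beyond the scatter), is large, and its size is set by the limit of > 10000 nM in this assay, at which 1 of the 2 values shown sits, so the true distance is not known.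

Compound 3 `COc1ccc(C2(NC(=O)CN3CCN(C)CC3)C(=O)Nc3cc(Cl)c(Cl)cc32)cc1` differs from compound 1 at another site: methoxy in place of chloro on an aromatic carbon. Among the measured compounds shown here, no measured step touches the pendant ring, so the step from compound 1 to compound 2 bears on it only in showing that the series can move far from the limit with one change. With compound 1 at a limit, the expected step of an at least 1.2-fold lower number from compound 1 to compound 3 (0.09 log units; that floor lies within the scatter) is uncertain in size and direction. Compound 3 is estimated at 8000 nM in this assay, within 1500 nM to 50000 nM.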

Compound 3, half-maximal inhibitory concentration: 700 nM
For compound 3 the middle estimate is 11-fold (1.06 log units) above the measured one; measured number below the stated range.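

The pendant ring is a second site that responds to change: with 4-chlorophenyl replaced by 4-methoxyphenyl and the shared core kept, this assay shows an at least 14-fold lower number from compound 1 to compound 3 (1.15 log units; beyond the scatter). Among the compounds shown here, the only earlier step was a change on the core, an at least 39-fold lower number from compound 1 to compound 2 (1.60 log units; beyond the scatter), so the weak end of the series can now be left by a single change at either of two separate places. Compound 1 stands at a limit and not at a number, so the true size of the new step is not known because of that limit: the limit of > 10000 nM in this assay, at which 1 of the 3 values shown sits.

Still open, as far as these compounds go, is what at this place on the aromatic ring carries the result, the oxygen of the methoxy group or the departure of the chlorine; hydroxy, ethoxy, methyl or fluoro at the same carbon would begin to separate the two. Also open, from the compounds shown here alone, is whether the two changes add up, which a compound with methyl in place of chloro on the core together with 4-methoxyphenyl as the pendant ring would show.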